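Swapping the amine on a dithiocarbamate in a chromone series

This account rests on a few compounds, and the source may have more. Where it says the series, first, only, none or still open, it means among the compounds named here.

Of the compounds shown here, three of a shared chromone-like scaffold have been tested in a functional assay on HeLa cells (Homo sapiens) for antiproliferative activity, read by MTT assay, with a stated time of 72 h; on this read-out lower numbers stand for stronger inhibition and higher numbers for weaker inhibition. Compound 1 `COc1ccc2oc(CSC(=S)N3CCOCC3)cc(=O)c2c1` reaches only the limit of the assay, at > 25000 nM. Compound 2 `COc1ccc2oc(CSC(=S)N(C(C)C)C(C)C)cc(=O)c2c1` likewise gives only a limit, at > 25000 nM. For the measured compounds named here, compound 3 `Cc1ccc2c(=O)c(CSC(=S)N(C(C)C)C(C)C)coc2c1`, whose core differs from that of compound 2 in a way that is not broken down here, is the one member with a real number: compound 3 gives 1400 nM in this assay.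

The change from compound 2 to compound 1 is morpholin-4-yl in place of diisopropylamino on a thiocarbonyl carbon. Its size is a step that the two limits leave unreadable from compound 2 to compound 1, because both partners sit at the same limit (the limit of > 25000 nM in this assay, at which 2 of the 3 values shown sit), so the measured pair reveals nothing about how large this swap can be.

Compound 4 `Cc1ccc2c(=O)c(CSC(=S)N3CCOCC3)coc2c1` has not yet been measured. It differs from compound 3 by morpholin-4-yl in place of diisopropylamino on a thiocarbonyl carbon, the same change as that from compound 2 to compound 1, made at the same place on the thiocarbonyl carbon. Going by the values given here, since the one earlier example of this change is unreadable, the expectation for compound 4 rests mainly on the value of compound 3 at 1400 nM, with a wide margin. The step from compound 3 to compound 4 in this assay is expected to be a 2.1-fold higher number from compound 3 to compound 4 (0.33 log units; beyond the scatter). Compound 4 is therefore estimated to give about 3000 nM, somewhere between 700 nM and 15000 nM.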

Compound 4, half-maximal inhibitory concentration: 6100 nM
Compound 4: middle estimate off by 2.0-fold (0.31 log units), on the low side, and the stated range covers the measured number.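

In this assay, putting morpholin-4-yl in place of diisopropylamino on a thiocarbonyl carbon gives a 4.4-fold higher number from compound 3 to compound 4 (0.64 log units; beyond the scatter), a modest weakening that lies beyond the usual scatter of repeated measurements. For the compounds shown here, this is the only readable example of the swap, so it gives the size of the change on one core and cannot by itself establish a rule for the whole series. The same swap on the other core cannot be read, and neither its size nor its direction can be compared with the new step, because compound 2 and compound 1 both sit at a limit of the assay, not at a number: the limit of > 25000 nM in this assay, at which 2 of the 4 values shown sit.

The compounds shown leave open how other amines on the thiocarbonyl carbon would behave on the core of compound 3, for example piperidin-1-yl, which is a six-membered ring like morpholin-4-yl but has a carbon where morpholin-4-yl has its oxygen, or the smaller dimethylamino. Such a comparison could help separate the contribution of that ring oxygen from that of the ring itself, while a readable pair on the core of compound 2 would be needed to test whether the swap carries across cores.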